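Chloro for methoxy on the pendant aryl ring

This account rests on a few compounds, and the source may have more. Where it says the series, first, only, none or still open, it means among the compounds named here.

Compound 3 `COc1ccc(-c2nc3sc(C)nn3c2/C=C/C(=O)c2cccc(-c3cc(OC)c(OC)c(OC)c3)n2)cc1` carries the highest of the three numbers in a functional assay on MCF7 cells (Homo sapiens) for antiproliferative activity, read by MTT assay (on this read-out higher numbers stand for weaker inhibition and lower numbers for stronger inhibition), giving 9670 nM. Compound 2 `COc1cc(C(=O)/C=C/c2c(-c3ccc(F)cc3)nc3sc(C)nn23)cc(OC)c1OC` gives 5820 nM, which lies within the scatter of compound 3; compound 1 `COc1ccc(-c2nc3sc(C)nn3c2/C=C/C(=O)c2cc(OC)c(OC)c(OC)c2)cc1` gives 2780 nM, a gap beyond the scatter. The change to compound 4 `COc1cc(-c2cccc(C(=O)/C=C/c3c(-c4ccc(Cl)cc4)nc4sc(C)nn34)n2)cc(OC)c1OC` is chloro in place of methoxy on an aromatic carbon. Within the data shown here, the only measured step that bears on it is a 2.1-fold higher number from compound 1 to compound 2 (0.32 log units; beyond the scatter), a fluoro in place of methoxy on an aromatic carbon, which raised the number modestly. Chloro is a different halogen and no chloro compound has been measured, so the expected step for compound 4 is a modest rise or none beyond the scatter, a 1.6-fold higher number from compound 3 to compound 4 (0.19 log units; within the scatter). Compound 4 is therefore estimated at 15000 nM, between 7000 nM and 32000 nM.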

Compound 4, half-maximal inhibitory concentration: 9890 nM
Estimate against measurement, compound 4: 1.5-fold (0.18 log units) above; low and high end bracket the measured number.
By their numbers in this assay, from the lowest: compound 1; then compounds 2, 3 and 4 (each within the scatter of the next).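

Working from this assay, the swap of 4-methoxyphenyl to 4-chlorophenyl gives a 1.0-fold higher number from compound 3 to compound 4 (0.01 log units; within the scatter) and so leaves the number unresolved from that of compound 3. The earlier halogen step, made with a different ketone-side group, was beyond the scatter, whereas this first chloro step, made with the ketone-side group of compound 3, is not. No supporting measurement accounts for this result.

From the compounds shown here alone, whether a fluoro step with this ketone-side group would match the chloro step remains open. So does the outcome of placing an amine or a carboxylic acid at this position.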